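Adding one aromatic methyl to compound 2

A few compounds are considered here, and "the series" means these few. Any claim that something is new, unique, unknown or untested is made for them only; others in the source may bear on it.

In a functional assay on KB cells (Homo sapiens) for cytotoxicity (a higher number here means that more compound is needed for the effect, a lower number that less compound is needed), compound 1 `CCc1ccc(/C=C/C(O)=C2/C(=O)C(C)=C(OC)C(C)(C)C2=O)cc1` gives 1.9 ug/mL and compound 2 `COC1=C(C)C(=O)/C(=C(O)/C=C/c2c(C)cccc2C)C(=O)C1(C)C` gives 2.1 ug/mL. Going by the values given here, these are the only two measured values, and they lie within the scatter of each other, so compound 2 stands level with compound 1.

Compound 3 `COC1=C(C)C(=O)/C(=C(O)/C=C/c2c(C)cc(C)cc2C)C(=O)C1(C)C` differs from compound 2 at one place: methyl in place of hydrogen on an aromatic carbon. The new methyl sits on an aromatic carbon, meta to two methyl groups and para to a large group.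

Among the compounds with values here, only one measured step bears on this change: a 1.1-fold higher number from compound 1 to compound 2 (0.04 log units; within the scatter). That step exchanges one alkyl-substituted aromatic ring for another and stays within the scatter. Within the data shown here, no measured step adds a single methyl at this carbon, so the evidence is thin, and the range has to stay wide. Even so, the one available step gives no reason to expect a shift in either direction. The estimated step is a 1.1-fold lower number from compound 2 to compound 3 (0.02 log units; within the scatter), which means no change beyond the scatter is expected. The estimate for compound 3 is 2 ug/mL, with an expected range of 1 ug/mL to 4 ug/mL.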

Compound 3, concentration for half-maximal effect: 1.84 ug/mL
Estimate against measurement, compound 3: 1.1-fold (0.04 log units) above; the range from low to high includes it.
By their numbers in this assay, from the lowest: compounds 3, 1 and 2 (each within the scatter of the next).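

In this assay, methyl in place of hydrogen on the aromatic carbon meta to two methyl groups and para to a large group gives a 1.1-fold lower number from compound 2 to compound 3 (0.06 log units; within the scatter). Going by these compounds alone, this is the first direct reading of a single methyl added at this carbon, whereas the earlier step exchanged one whole substituted aromatic group for another; the added methyl is tolerated here, with no change beyond the scatter. No measurement on hand offers an explanation for this flat result, or shows what the added methyl does to the compound beyond this cytotoxicity read-out.

With the two methyl groups kept in place, the compounds shown carry only hydrogen or methyl on this carbon, so the reading covers just the smallest change and does not show how far the position stays insensitive. A longer chain such as propyl, a hydroxyl, an amine or a carboxylic acid at this carbon would show whether the number stays level once the group differs in size or kind.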